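Two limits and one untested ring swap

This account rests on a few compounds, and the source may have more. Where it says the series, first, only, none or still open, it means among the compounds named here.

Compound 1 `COc1cccc(-c2nc3c(c(C)nn3-c3ccccc3)c(-c3ccccc3O)c2C#N)c1`: > 23000 nM
Compound 2 `Cc1nn(-c2ccccc2)c2nc(-c3ccc4c(c3)CCCC4)c(C#N)c(-c3ccccc3O)c12`: > 20000 nM

Both entries come from an ADME assay on BJ cells (Homo sapiens) for cytotoxicity, with a stated time of 72 h (on this read-out higher numbers stand for an effect only at larger amounts of compound and lower numbers for an effect already at smaller amounts), and neither is a number. Compound 1 gives > 23000 nM, which is a limit of the assay. Compound 2 gives > 20000 nM, which is also a limit of the assay, so its standing is known only as the limit of > 20000 nM in this assay, at which 1 of the 2 values shown sits.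

The next compound, compound 3 `Cc1nn(-c2ccccc2)c2nc(-c3ccc4c(c3)OCCO4)c(C#N)c(-c3ccccc3O)c12`, differs from compound 2 by one change: 2,3-dihydro-1,4-benzodioxin-6-yl in place of 1,2,3,4-tetrahydronaphthalen-6-yl on an aromatic carbon. In words, 2,3-dihydro-1,4-benzodioxin-6-yl replaces 1,2,3,4-tetrahydronaphthalen-6-yl on an aromatic carbon.

Going by the values given here, only one measured step bears on this change, and it concerns a swap of group on that same carbon: a step that the two limits leave unreadable from compound 1 to compound 2. It offers no size to carry over, and no measured change in this assay points in either direction. A step beyond the usual scatter is therefore not expected, and another limit is the most likely report.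

The estimated step is a step that the limit leaves unreadable from compound 2 to compound 3. For compound 3 the expected value is 22000 nM, with an estimated range of 10000 nM to 45000 nM.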

Compound 3, half-maximal effective concentration in the BJ assay: > 20000 nM
Compound 3: a limit, no number; the forecaster's own chance of this, stated with the estimate: 80%; the middle value is on the limit's open side.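

In the BJ assay compound 3 gives > 20000 nM, which is a limit of the assay and not a number. Compound 1 and compound 2 also give only limits, so no step among these three compounds can be read: the limit of > 20000 nM in the BJ assay, at which 2 of the 3 values shown sit.

The compounds shown leave open at what amount any of them acts on these cells, and whether the 3-methoxyphenyl, 1,2,3,4-tetrahydronaphthalen-6-yl and 2,3-dihydro-1,4-benzodioxin-6-yl groups differ at all on this read-out.

In a physicochemical assay for solubility, read by spectrophotometry, in phosphate buffer, with a stated time of 18 h, at pH 7.4 (on this read-out lower numbers stand for lower solubility and higher numbers for higher solubility), compound 2 gives 13000 nM and compound 3 gives 11000 nM, which is a 1.2-fold lower number from compound 2 to compound 3 (0.07 log units; within the scatter).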